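The source may report more compounds than this note shows. Statements on the series, on what has been measured and on what is new or still open speak of the compounds shown alone.

Compound 1 `CN(C)CCC(=O)Nc1cccc(-c2nc3ccccc3s2)c1` — in an ADME assay on HEK293 cells (Homo sapiens) for inhibition, with a stated time of 72 h (on this read-out lower numbers stand for an effect already at smaller amounts and higher numbers for an effect only at larger amounts of compound), compound 1 gives > 25000 nM, a limit of the assay.
Compound 2 `CC(Cl)C(=O)Nc1cccc(-c2nc3ccccc3s2)c1` — in this assay compound 2 gives > 25000 nM, a limit.
Compound 3 `O=C(Nc1cccc(-c2nc3ccccc3s2)c1)c1cnccc1Cl` — in this assay compound 3 gives > 25000 nM, again a limit.

Compound 3 therefore stands only at a limit, and no number marks it out from the other two members of the series, since (the limit of > 25000 nM in this assay, at which 3 of the 3 values shown sit). The step to compound 4 `O=C(Nc1cccc(-c2nc3ccccc3s2)c1)c1ccnc(Cl)c1` is 2-chloropyridin-4-yl in place of 4-chloropyridin-3-yl on a carbonyl carbon. The measured steps that bear on it are the three exchanges on the carbonyl carbon: a step that the two limits leave unreadable from compound 1 to compound 2, a step that the two limits leave unreadable from compound 1 to compound 3 and a step that the two limits leave unreadable from compound 2 to compound 3, none of them readable in size because of the limit of > 25000 nM in this assay, at which 3 of the 3 values shown sit. Compound 4 exchanges one chloropyridinyl for another on the same carbonyl carbon, and nothing measured in the series points to a shift in this assay large enough to bring a value inside the working range. The expected step from compound 3 to compound 4 is a step that the limit leaves unreadable from compound 3 to compound 4, that is, no step beyond the scatter. For compound 4 the estimate in this assay is 40000 nM, expected to lie between 20000 nM and 120000 nM, most probably reported once more only as a limit.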

Compound 4, half-maximal effective concentration: > 25000 nM
Compound 4 ended at the assay's limit (the forecaster's own chance of this, stated with the estimate: 85%); the middle value is on the limit's open side.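

Among these compounds, no step from compound 1, compound 2 or compound 3 to compound 4 can be read in this assay, since every value is only a limit: the limit of > 25000 nM in this assay, at which 4 of the 4 values shown sit. The compounds shown leave open where any of the four would fall on a measured scale, and whether any exchange on the carbonyl carbon changes the read-out.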